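Adding a Phenyl Group to a Brominated Salicylanilide

The source may hold more compounds than are shown below. What is called first, only, known or untested is meant among the compounds shown, and "the series" means these compounds.

The series shares an amide linking a bis(trifluoromethyl)phenyl group to a hydroxy-substituted benzoyl core, and is followed in a functional assay on HL-60 cells (Homo sapiens) for cytotoxicity, read by luminescence and CellTiter-Glo, with a stated time of 3 days; a lower number here means a stronger inhibitor, a higher number a weaker inhibitor. Compound 1 `O=C(Nc1cc(C(F)(F)F)cc(C(F)(F)F)c1)c1cc(Cl)c(-c2ccccc2)cc1O` carries a phenyl ring on its core and gives 790 nM. Compound 2 `O=C(Nc1cc(C(F)(F)F)cc(C(F)(F)F)c1)c1cc(Br)ccc1O` gives 290 nM, and compound 3 `O=C(Nc1cc(C(F)(F)F)cc(C(F)(F)F)c1)c1ccc(Cl)cc1O` gives 200 nM. Compound 2 stands second highest among these three numbers; its nearest neighbour is compound 3, and the step of a 1.5-fold lower number from compound 2 to compound 3 (0.16 log units; within the scatter) lies within the scatter, while compound 1 sits a clear distance higher.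

Compound 4 `O=C(Nc1cc(C(F)(F)F)cc(C(F)(F)F)c1)c1cc(Br)c(-c2ccccc2)cc1O` differs from compound 2 by phenyl in place of hydrogen on an aromatic carbon. Among the measured compounds shown here, no single measured step shows this change on its own: compound 1 differs from compound 3 both in its halogen arrangement and in carrying the phenyl, so those two values can only be read together. For the measured compounds named here, they do show that the one phenyl-bearing compound has the highest number of the set. On that basis compound 4 is expected to give a higher number than compound 2 in this assay, with an estimated step of a 2.4-fold higher number from compound 2 to compound 4 (0.38 log units; beyond the scatter). Compound 4 is thus estimated at 700 nM, within a range from 250 nM to 2000 nM.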

Compound 4, half-maximal inhibitory concentration: 430 nM
Compound 4: the middle estimate sits 1.6-fold (0.21 log units) above what was measured; measured number inside the range.
By their numbers in this assay, from the lowest: compounds 3, 2, 4 and 1 (each within the scatter of the next, the first and the last beyond it).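

In this assay, among the compounds shown here, phenyl in place of hydrogen gives a 1.5-fold higher number from compound 2 to compound 4 (0.17 log units; within the scatter), the first reading of this change on its own, and it shows that a whole aromatic ring can sit on this carbon, ortho to a bromo group, meta to a hydroxy group and para to a large group, without a step that stands clear of the scatter. With the phenyl in place on both compounds, bromo in place of chloro gives a 1.8-fold lower number from compound 1 to compound 4 (0.26 log units; within the scatter), so the two halogens cannot be told apart at this position of the phenyl-bearing core, and the earlier link between the phenyl and the highest number of the set does not hold up as a clear effect of the phenyl alone. Nothing available here bears on why this carbon accepts the added ring.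

The compounds shown leave open whether this carbon would accept other groups, such as a methyl, a methoxy or a morpholine ring, as readily as it accepts phenyl. They also leave open whether a carboxylic acid or an amine placed on the added phenyl ring would move the number beyond the scatter.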